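The source may report more compounds than this note shows. Statements on the series, on what has been measured and on what is new or still open speak of the compounds shown alone.

Working notes on the series. Of the compounds shown here, three of the shared core have been measured in a functional assay on HepG2 cells (Homo sapiens) for cytotoxicity, with a stated time of 24 h; on this read-out higher numbers stand for weaker inhibition and lower numbers for stronger inhibition. Compound 1 `COc1ccc(C(=O)N/N=C/c2cc(I)cc(I)c2O)cc1` gives 45200 nM, compound 2 `O=C(N/N=C/c1cc(I)cc(I)c1O)c1ccc(O)cc1` gives 19200 nM, and compound 3 `O=C(N/N=C/c1cc(I)cc(I)c1O)c1ccc(Cl)cc1` gives 14800 nM. Compound 2 stands second highest of the three numbers: the step of a 2.4-fold lower number from compound 1 to compound 2 (0.37 log units; beyond the scatter) lies beyond the scatter, whereas the step of a 1.3-fold lower number from compound 2 to compound 3 (0.11 log units; within the scatter) stays within it.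

The next compound, compound 4 `O=C(N/N=C/c1cc(I)cc(I)c1O)c1ccc(C(F)(F)F)cc1`, is derived from compound 2 by the change (trifluoromethyl in place of hydroxy on an aromatic carbon), on an aromatic carbon of a six-membered aromatic ring of carbon only, para to a large group; a group with one hydrogen-bond donor and one acceptor leaves, and a group with four heavy atoms and no donor or acceptor enters.

Within the data shown here, two measured steps concern exchanges at this same aromatic carbon. The step of a 3.1-fold lower number from compound 1 to compound 3 (0.48 log units; beyond the scatter) was modest, and the step of a 1.3-fold lower number from compound 2 to compound 3 (0.11 log units; within the scatter) was within the scatter. On this basis the expected step of a 1.6-fold lower number from compound 2 to compound 4 (0.20 log units; within the scatter) is at most modest, towards a lower number if anything, and may well fall within the scatter. Compound 4 is therefore estimated at 12000 nM in this assay, with an expected range from 5000 nM to 30000 nM.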

Compound 4, half-maximal inhibitory concentration: 11700 nM
For compound 4 the middle estimate is 1.0-fold (0.01 log units) above the measured one, and the stated range covers the measured number.
By their numbers in this assay, from the lowest: compounds 4, 3 and 2 (each within the scatter of the next); then compound 1.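

In this assay trifluoromethyl, with 0 hydrogen-bond donors and 0 hydrogen-bond acceptors, cannot be told apart from the groups it replaces at this aromatic carbon: the result is a 1.6-fold lower number from compound 2 to compound 4 (0.22 log units; within the scatter) for the exchange with hydroxy and a 1.3-fold lower number from compound 3 to compound 4 (0.10 log units; within the scatter) for the exchange with chloro. Compounds 2, 3 and 4 thus form one group within the scatter of each other, so neither the loss of the hydroxy donor and acceptor nor the rise to four heavy atoms gives a resolved change, and compound 1 alone stands apart, with a 3.9-fold lower number from compound 1 to compound 4 (0.59 log units; beyond the scatter) adding a third step beyond the scatter from its methoxy group. Nothing available on these compounds accounts for the separate position of compound 1.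

As far as these compounds go, whether an amine, a carboxylic acid or a longer chain such as ethoxy at this aromatic carbon would join compounds 2, 3 and 4 or stand with compound 1 remains open. The compounds shown also leave open whether this grouping holds once the shared core itself is changed.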